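Adding chloro to compound 1: an expected shift

The source may report more compounds than this note shows. Statements on the series, on what has been measured and on what is new or still open speak of the compounds shown alone.

Measured so far in a physicochemical assay for lipophilicity, at pH 7.4 (a higher number here means a more lipophilic compound, a lower number a more polar compound), are three compounds.

- Compound 1 `Cc1[nH]c2ccccc2c(=O)c1Cc1ccccc1` gives 1.93
- Compound 2 `Cc1[nH]c2ccccc2c(=O)c1/C=C/C(=O)OC(C)(C)C` gives 2.34
- Compound 3 `CCCCC#Cc1c(C)[nH]c2ccccc2c1=O` gives 5.44

Compound 1 has the lowest number of the three. Compound 2 is its nearest neighbour and lies higher, by more than the usual scatter of repeated measurements. Compound 3 lies much higher, also well beyond that scatter.

The next compound to be measured is compound 4 `Cc1[nH]c2ccc(Cl)cc2c(=O)c1Cc1ccccc1` which keeps the core of compound 1 and changes in one place. It carries chloro in place of hydrogen on an aromatic carbon and the rest of the structure stays the same. Within the data shown here, no two measured compounds differ by this swap, so the data offer no direct precedent for it. Compounds 2 and 3 differ from compound 1 in another part of the structure and say little about this change.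

A single added chlorine is a small edit, so a modest upward move in this assay is expected, far short of the gap separating compound 3 at 5.44 from the other two. The expected change is estimated as a number 0.67 log units higher from compound 1 to compound 4 (beyond the scatter) in the upward direction. For compound 4 the estimated value is 2.6 with an expected range from 2.1 to 3.2 on this scale.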

Compound 4, distribution coefficient: 2.79
Beside the measured number, compound 4's estimate is 0.19 log units below it, and the stated range covers the measured number.
By their numbers in this assay, from the lowest: compound 1; then compound 2; then compound 4; then compound 3.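

Placing chloro in place of hydrogen on an aromatic carbon gives, in this assay, a number 0.86 log units higher from compound 1 to compound 4 (beyond the scatter) and provides the first direct reading of this swap in the series, with the rest of the structure unchanged. Compounds 1, 2 and 3 all carry hydrogen at this place, so they could not show what a substituent there does; compound 4 now shows that a single chlorine on this carbon, meta to a fused ring and para to a fused ring, moves the number upward by more than the usual scatter of repeated measurements. The compounds shown include no separate measurement that would explain the size of this step.

From the compounds shown here alone, it remains open whether another group at this same place, such as fluoro, methoxy, an amine or a carboxylic acid, would move the number in the same direction or by a similar amount. Going by these compounds, it is also open whether chloro at another carbon of this ring, or the same swap made on compound 2 or compound 3, would give a step of similar size.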